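A Fluoro Swap in Place of Iodo

The source may report more compounds than this note shows. Statements on the series, on what has been measured and on what is new or still open speak of the compounds shown alone.

For the measured compounds named here, in a functional assay on DU-145 cells (Homo sapiens) for inhibition, read by trypan blue exclusion, with a stated time of 96 h (a higher number here means a weaker inhibitor of growth, a lower number a stronger inhibitor of growth), compound 2 (`O=C(/C(=C\c1ccc(I)cc1)S(=O)(=O)c1ccc(Br)cc1)c1ccc(Br)cc1`) gives 1000 nM and holds the lower of the two numbers so far, while compound 1 (`O=C(/C(=C\c1ccc(OC(F)(F)F)cc1)S(=O)(=O)c1ccc(Br)cc1)c1ccc(Br)cc1`) gives 25000 nM in the same test. Compound 3 (`O=C(/C(=C\c1ccc(F)cc1)S(=O)(=O)c1ccc(Br)cc1)c1ccc(Br)cc1`) follows from compound 2 through one change, (fluoro in place of iodo on an aromatic carbon), with fluoro in place of iodo on an aromatic carbon. Going by the values given here, only one measured step bears on it, made at the same place on the ring: iodo in place of trifluoromethoxy gave a 25-fold lower number from compound 1 to compound 2 (1.40 log units; beyond the scatter) and was large. Among the compounds with values here, no fluoro compound has been measured, so that step shows only that this place can matter. Loss of the iodo of compound 2 is expected to raise the number, though by less than that step. The step expected in this assay is a 3.0-fold higher number from compound 2 to compound 3 (0.48 log units; beyond the scatter) and is moderate. Compound 3 is estimated at 3000 nM with a range from 800 nM to 12000 nM in this test.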

Compound 3, concentration for 50% growth inhibition: 4000 nM
For compound 3 the middle estimate is 1.3-fold (0.12 log units) below the measured one; the range from low to high includes it.
By their numbers in this assay, from the lowest: compound 2; then compound 3; then compound 1.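

In this assay, fluoro matches neither iodo nor trifluoromethoxy at this place on the aromatic ring: the swap from iodo to fluoro gives a 4.0-fold higher number from compound 2 to compound 3 (0.60 log units; beyond the scatter), while the swap from trifluoromethoxy to fluoro gives a 6.3-fold lower number from compound 1 to compound 3 (0.80 log units; beyond the scatter). Iodo is therefore not the only group here that gives a number well under that of compound 1, although it gives the lowest number of the three, and the position shows a graded series rather than a single large jump. Nothing available here explains why the three groups fall in this order.

As far as these compounds go, whether chloro or bromo at this place would fall between fluoro and iodo remains open, as does the effect of an amine or a carboxylic acid there. It is also unknown whether the same order would hold with other groups elsewhere on the shared core.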